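The source may report more compounds than this note shows. Statements on the series, on what has been measured and on what is new or still open speak of the compounds shown alone.

Compound 3 `N[C@@H](C(=O)NCc1ccccc1)C1CCCCC1` gives 28 mg/kg in a functional assay on the whole organism (strain NMRI) with Mus musculus as the target, in the maximal electroshock model, with a stated time of 30 min; a lower number here means that less compound is needed, a higher number that more compound is needed for the effect. Of the two numbers recorded, compound 3 is the higher one; compound 2 `CCCC[C@@H](N)C(=O)NCc1ccccc1` gives 23 mg/kg in this assay, which lies within the scatter of compound 3. Going by the values given here, the step of a 1.2-fold higher number from compound 2 to compound 3 (0.09 log units; within the scatter) is the only measured step in the set. Compound 1 `NCC(N)C(=O)NCc1ccccc1` gives in this assay only a limit of the assay, > 68 mg/kg, and not a number. That third value is therefore a limit only (the limit of > 68 mg/kg in this assay, at which 1 of the 3 values shown sits).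

Compound 4 `N[C@H](CCO)C(=O)NCc1ccccc1` differs from compound 3 by 2-hydroxyethyl in place of cyclohexyl on a saturated chain carbon bound to an amine nitrogen and a carbonyl carbon. Among the compounds with values here, no measured step places a 2-hydroxyethyl on this carbon. Within the data shown here, the one measured step, a 1.2-fold higher number from compound 2 to compound 3 (0.09 log units; within the scatter), exchanged one hydrocarbon group for another and stayed within the scatter, so it bears little on this change. The closest comparison is compound 1, whose result in this assay was a limit rather than a number. On that basis the expected step is a 2.5-fold higher number from compound 3 to compound 4 (0.40 log units; beyond the scatter). Compound 4 is estimated at 70 mg/kg in this assay, within a range from 35 mg/kg to 140 mg/kg, with a real chance that only a limit is reported.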

Compound 4, dose for half-maximal effect: > 160 mg/kg
Compound 4 was reported as a limit (the forecaster's own chance of this, stated with the estimate: 50%); at least 2.2-fold (0.35 log units) between middle value and limit.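

In this assay, going by these compounds alone, 2-hydroxyethyl on the saturated chain carbon bound to an amine nitrogen and a carbonyl carbon gives the first readable step at this position that lies beyond the scatter: an at least 5.7-fold higher number from compound 3 to compound 4 (0.75 log units; beyond the scatter), while the exchange of one hydrocarbon group for another, a 1.2-fold higher number from compound 2 to compound 3 (0.09 log units; within the scatter), stayed within it. Against the open-chain butyl group the change reads an at least 6.9-fold higher number from compound 2 to compound 4 (0.84 log units; beyond the scatter), so the result does not depend on the loss of the cyclohexyl ring alone; among compound 2, compound 3 and compound 4, only the two hydrocarbon groups give a number at this position. Compound 4 stands only as a limit, and its step to compound 1 cannot be read, as both results are limits: the limit of > 160 mg/kg in this assay, at which 1 of the 4 values shown sits.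

The compounds shown do not separate the effect of the hydroxy group from that of the shorter chain, a question that a plain ethyl group or a 4-hydroxybutyl group on this carbon would address. Also open, going by these compounds, is whether a methoxyethyl group, with the hydroxy hydrogen replaced by methyl, would give a number in this assay or another limit.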